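Trifluoromethyl placement on the aromatic ring of compound 1

The compounds below may be only part of what the source reports. "The series", "measured", "known", "first", "only" and "open" are said of these compounds alone.

Compound 1 `COC(=O)c1nc(C)n(-c2ccccc2)n1` is the unsubstituted parent of this short set. In a functional assay on NCI-H226 cells (Homo sapiens) for inhibition, read by MTT assay, with a stated time of 72 h (on this read-out higher numbers stand for weaker inhibition of growth and lower numbers for stronger inhibition of growth), compound 1 gives > 100000 nM, which is a limit of the assay rather than a number (the limit of > 100000 nM in this assay, at which 1 of the 3 values shown sits). Two measured compounds carry a trifluoromethyl group on the six-membered aromatic ring of carbon only. Compound 2 `COC(=O)c1nc(C)n(-c2ccccc2C(F)(F)F)n1` gives 6130 nM in this assay, a step of an at least 16-fold lower number from compound 1 to compound 2 (1.21 log units; beyond the scatter). Compound 3 `COC(=O)c1nc(C)n(-c2cccc(C(F)(F)F)c2)n1` gives 14300 nM in this assay, a step of an at least 6.9-fold lower number from compound 1 to compound 3 (0.84 log units; beyond the scatter). Both steps run in the same direction and beyond the scatter; their sizes are lower bounds because compound 1 sits at the limit (the limit of > 100000 nM in this assay, at which 1 of the 3 values shown sits).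

Compound 4 `COC(=O)c1nc(C)n(-c2ccc(C(F)(F)F)cc2)n1` is not yet measured. It differs from compound 1 by trifluoromethyl in place of hydrogen on an aromatic carbon, the entering group sitting para to a large group. The two measured placements of the same group both gave clearly lower numbers, so a step of the same kind is expected here, of a size near those two steps rather than larger. The expected step is an at least 6.6-fold lower number from compound 1 to compound 4 (0.82 log units; beyond the scatter). Compound 4 is therefore estimated at 15000 nM, with a range of 4000 nM to 60000 nM.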

Compound 4, concentration for 50% growth inhibition: 16600 nM
The estimate for compound 4 lay 1.1-fold (0.04 log units) below the measured number; the measured number falls inside the stated range.
By their numbers in this assay, from the lowest: compound 2; then compounds 3 and 4 (each within the scatter of the next). At a limit, above all of these: compound 1.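

Trifluoromethyl para to a large group also gives an at least 6.0-fold lower number from compound 1 to compound 4 (0.77 log units; beyond the scatter), so all three placements shown now stand clear of compound 1 in this assay and the change does not depend on a single position on the ring. Compound 3 and compound 4 lie within the scatter of each other, so these two placements cannot be told apart on this read-out, while compound 2 gives 6130 nM, the lowest number of the set. The sizes of all three steps remain lower bounds only: the limit of > 100000 nM in this assay, at which 1 of the 4 values shown sits.

The compounds shown leave open whether the lower numbers belong to trifluoromethyl itself or would also follow from a chlorine, a methoxy group or an amine on the same ring. They also say nothing about the methyl ester, since a carboxylic acid or an amide in its place lies outside this set.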